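The source may report more compounds than this note shows. Statements on the series, on what has been measured and on what is new or still open speak of the compounds shown alone.

Compound 1 `CN(C)c1ncnc2c1ncn2Cc1ccc(Cl)cc1` and compound 2 `COc1ccc(Cn2cnc3c(N(C)C)ncnc32)cc1` share one core and differ only by methoxy in place of chloro on an aromatic carbon. In a functional assay on the whole organism for inhibition, with Rattus norvegicus as the target, in the maximal electroshock model, at a dose of 25 mg/kg by the intraperitoneal route (a lower number here means less inhibition, a higher number more inhibition at the dose given (going by the name of the read-out)), compound 1 gives 0%, and compound 2 gives 0%, so the step of no change at the digits printed from compound 1 to compound 2 (within the scatter) is flat. Compound 3 `CN(C)c1ncnc2c1ncn2Cc1ccccc1Cl` is made of the same atoms as compound 1, joined differently; the difference between the two cores is not broken down here. In this assay compound 3 gives 84%, the highest of the three numbers and beyond the scatter away from both compound 1 and compound 2. Compound 4 `COc1ccccc1Cn1cnc2c(N(C)C)ncnc21` has not been measured. Among the compounds with values here, it differs from compound 3 by methoxy in place of chloro on an aromatic carbon, the same kind of change as the one from compound 1 to compound 2, but here the place is ortho to a large group rather than para to a large group. The earlier step started from a pair of compounds whose numbers in this assay were both at the lowest level, so it says little about what the change does on a core whose number is high. The step from compound 3 to compound 4 is therefore expected to be a number 34 percentage points lower from compound 3 to compound 4 (beyond the scatter), an estimate with wide margins. Compound 4 is expected to give 50% in this assay, somewhere between 10% and 90%.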

Compound 4, a percentage reported as inhibition, in the whole organism at one dose (the size of the read-out at that dose, not a potency): 0%
The estimate for compound 4 lay 50 percentage points above the measured number; measured number outside the range, below it.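

In this assay, methoxy in place of chloro, ortho to a large group, gives a number 84 percentage points lower from compound 3 to compound 4 (beyond the scatter). The effect of this change on one core therefore cannot be assumed to carry over to another in this series, as the two steps differ: the same change on two cores in this assay, no change at the digits printed (within the scatter) from compound 1 to compound 2 and a number 84 percentage points lower (beyond the scatter) from compound 3 to compound 4, 84 percentage points apart, beyond the scatter of two such steps

Within the data shown here, this does not show why they differ, and the comparison has clear limits: the earlier step started from the lowest level of the read-out, where a fall could not appear, and the two cores are represented by only one such pair each.

Going by these compounds, only chloro and methoxy appear on this ring among the compounds with the substituent ortho to a large group, so it stays open whether fluoro, methyl or trifluoromethyl there would keep a number like that of compound 3, 84%. Also open, on these data alone, is how a different amine in place of the dimethylamino group, or a longer chain linking the aromatic ring to the shared core, would behave in this assay.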